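This account rests on a few compounds, and the source may have more. Where it says the series, first, only, none or still open, it means among the compounds named here.

Working notes on the series. Three analogues share one core and differ only in one aryl group: compound 1 `CC1=NN(c2ccccc2)C(=O)[C@]12C(=O)C=CC[C@@H]2c1ccc(C)cc1`, compound 2 `CC1=NN(c2ccccc2)C(=O)[C@]12C(=O)C=CC[C@@H]2c1cccc(C)c1` and compound 3 `CC1=NN(c2ccccc2)C(=O)[C@]12C(=O)C=CC[C@@H]2c1ccccc1`. In a functional assay on MDA-MB-231 cells (Homo sapiens) for inhibition, read by MTT assay, with a stated time of 72 h (a higher number here means a weaker inhibitor, a lower number a stronger inhibitor), compound 1 gives 6240 nM, compound 2 gives 8000 nM and compound 3 gives 9080 nM. Compound 1 is not separated from either of the other two, and all three sit together within the scatter. The steps read a 1.3-fold higher number from compound 1 to compound 2 (0.11 log units; within the scatter) and a 1.5-fold higher number from compound 1 to compound 3 (0.16 log units; within the scatter).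

The next analogue is compound 4 `CC1=NN(c2ccc(C)cc2)C(=O)[C@]12C(=O)C=CC[C@@H]2c1ccc(C)cc1`. It carries methyl in place of hydrogen on an aromatic carbon, phenyl to 4-methylphenyl, on the phenyl that stays unchanged across the three measured compounds: methyl in place of hydrogen on an aromatic carbon. Among the measured compounds shown here, no measured step touches that phenyl, so the evidence is by analogy only. The nearest guides are the same exchange, read in reverse, on the other aryl group: a 1.5-fold higher number from compound 1 to compound 3 (0.16 log units; within the scatter) and a 1.1-fold higher number from compound 2 to compound 3 (0.05 log units; within the scatter). Both are small, so no shift beyond the scatter is expected in this assay, in either direction. The estimated step is a 1.1-fold lower number from compound 1 to compound 4 (0.05 log units; within the scatter). For compound 4 the expected value is 5500 nM, with an estimated range of 2800 nM to 11000 nM.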

Compound 4, half-maximal inhibitory concentration: 57200 nM
Compound 4: middle estimate off by 10-fold (1.02 log units), on the low side, and the stated range ends below it.
By their numbers in this assay, from the lowest: compounds 1, 2 and 3 (each within the scatter of the next); then compound 4.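

In this assay, the step is a 9.2-fold higher number from compound 1 to compound 4 (0.96 log units; beyond the scatter), the first in the series to lie beyond the scatter, and it falls on the phenyl that stays unchanged in compounds 1, 2 and 3. Among the compounds shown here, replacing hydrogen with methyl on this ring therefore weakens the compound, so this position is sensitive to the change in a way the earlier steps on the other aryl group gave no sign of. The same exchange does not read alike at the two aryl groups, so a small step at one gives no guide to the other: the same change on two cores in this assay, a 1.1-fold higher number (0.05 log units; within the scatter) from compound 2 to compound 3 and a 9.2-fold lower number (0.96 log units; beyond the scatter) from compound 4 to compound 1, 10-fold (1.02 log units) apart, beyond the scatter of two such steps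

The compounds shown leave open whether the loss is specific to methyl or would also appear with a fluorine, a methoxy group, a hydroxyl group or a carboxylic acid at the same place, and whether methyl elsewhere on this phenyl behaves the same way. They also leave open whether 4-methylphenyl here costs as much when the other aryl group is the unsubstituted phenyl of compound 3 rather than the 4-methylphenyl of compound 1.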